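Removing the indole bromo on compound 3

A few compounds are considered here, and "the series" means these few. Any claim that something is new, unique, unknown or untested is made for them only; others in the source may bear on it.

The series shares one hydrazone core linking a benzyl-substituted indole to an indole carboxamide, and is followed in a functional assay on LNCaP cells (Homo sapiens) for cytotoxicity; on this read-out lower numbers stand for stronger inhibition and higher numbers for weaker inhibition. Compound 1 `COc1ccc(Cn2cc(/C=N\NC(=O)c3c[nH]c4ccccc34)c3ccccc32)cc1` gives 31900 nM. Compound 2 `O=C(N/N=C\c1cn(Cc2ccc(Cl)cc2)c2cc(F)ccc12)c1c[nH]c2ccccc12`, carrying a chloro on the benzyl and a fluoro on the first indole, gives 55200 nM. Compound 3 `COc1ccc(Cn2cc(/C=N\NC(=O)c3c[nH]c4ccc(Br)cc34)c3ccc(F)cc32)cc1` adds a bromo on the carboxamide indole and a fluoro on the first indole. For compound 3 this assay returns only a limit, > 100000 nM, and not a number; it stands at the limit of > 100000 nM in this assay, at which 1 of the 3 values shown sits, so its place relative to compounds 1 and 2 is not fixed by the data.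

Compound 4 `COc1ccc(Cn2cc(/C=N\NC(=O)c3c[nH]c4ccccc34)c3ccc(F)cc32)cc1` is compound 3 with one change: hydrogen in place of bromo on an aromatic carbon. Among the measured compounds shown here, no pair in the measured set differs only in this bromo, so the size of its effect is not known. Both compounds without a bromo on that indole, compound 1 at 31900 nM and compound 2 at 55200 nM, give a number in this assay. Compound 3, by contrast, is only cut off at its limit. Going by these compounds, for compound 4 the expected step is therefore a move toward a lower number, an at least 2.2-fold lower number from compound 3 to compound 4 (0.34 log units; beyond the scatter), though the true size of that step stays open. For compound 4 in this assay the estimate is 45000 nM, in the range 20000 nM to 100000 nM, with a fair chance that only a limit is returned again.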

Compound 4, half-maximal inhibitory concentration: > 100000 nM
Compound 4: no number, only a limit (the forecaster's own chance of this, stated with the estimate: 25%); at least 2.2-fold (0.34 log units) between middle value and limit.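

Compound 4 returns only a limit in this assay, so the change from 5-bromo-1H-indol-3-yl to 1H-indol-3-yl cannot be read as a step, and losing the bromo does not by itself bring a number back. The fluoro now has a readable trace: with fluoro in place of hydrogen on an aromatic carbon, the series shows an at least 3.1-fold higher number from compound 1 to compound 4 (0.49 log units; beyond the scatter), while methoxy in place of chloro on an aromatic carbon gives an at least 1.8-fold higher number from compound 2 to compound 4 (0.25 log units; that floor lies within the scatter), so compound 2 stands against any simple rule that the fluoro alone pushes a compound to the limit. The top of the read-out is now a shared ceiling for the two compounds that carry both the fluoro and the methoxy: the limit of > 100000 nM in this assay, at which 2 of the 4 values shown sit.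

Going by these compounds, whether the bromo has any effect at all stays open, and so does the true size of both readable steps beyond their floors. On these data alone, how an amine or a carboxylic acid in place of the bromo would read is also open, as is whether a number can be recovered at this place while the fluoro and methoxy remain.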